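A few compounds are considered here, and "the series" means these few. Any claim that something is new, unique, unknown or untested is made for them only; others in the source may bear on it.

Measured compounds:
compound 1 `C[C@H](NC(=O)C(=O)Nc1ccccc1F)C(=O)N[C@@H](CC(=O)O)C(=O)COc1c(F)c(F)cc(F)c1F`: 160 nM
compound 2 `C[C@H](NC(=O)C(=O)Nc1ccccc1-c1ccccc1)C(=O)N[C@@H](CC(=O)O)C(=O)COC(=O)c1c(F)c(F)cc(F)c1F`: 130 nM

Both numbers come from a functional assay on Jurkat cells (Homo sapiens) for inhibition; on this read-out lower numbers stand for stronger inhibition and higher numbers for weaker inhibition. Among these two, compound 1 stands highest, but compound 2 lies within the scatter, so no order between them can be read. Compound 3 `C[C@H](NC(=O)C(=O)Nc1ccccc1Oc1ccccc1)C(=O)N[C@@H](CC(=O)O)C(=O)COc1c(F)c(F)cc(F)c1F` is not yet measured; it differs from compound 1 by phenoxy in place of fluoro on an aromatic carbon. For the measured compounds named here, no single-change pair has been measured, but there is compound 2, which also carries a six-membered carbon ring where compound 1 has fluoro while differing in a second place. In this assay compound 2 gives 130 nM. The step of a 1.2-fold lower number from compound 1 to compound 3 (0.09 log units; within the scatter) is therefore expected to stay within the scatter. Compound 3 is estimated at 130 nM, with a range from 55 nM to 320 nM.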

Compound 3, half-maximal inhibitory concentration: 530 nM
For compound 3 the middle estimate is 4.1-fold (0.61 log units) below the measured one; the whole stated range lies below it.
By their numbers in this assay, from the lowest: compounds 2 and 1 (each within the scatter of the next); then compound 3.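

In this assay, phenoxy in place of fluoro on this aromatic carbon, ortho to a large group, gives a 3.3-fold higher number from compound 1 to compound 3 (0.52 log units; beyond the scatter). This single-change pair shows that inhibition in these cells responds to what sits at this position, and that here the swap to phenoxy weakens it. No measurement is available that could explain the step. Still open, on these data alone, is how a methoxy group or an amine on the same carbon would compare with fluoro and phenoxy. Also open, as far as these compounds go, is whether the step would keep its size on a different core.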